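The compounds below may be only part of what the source reports. "The series", "measured", "known", "first", "only" and "open" are said of these compounds alone.

Measured so far:
compound 1, `O=C(Nc1ccccc1C(F)(F)F)C1CCc2ccccc2N1C(=O)c1cccc(Cl)c1`, 729 nM
compound 2, `COc1ccc(NC(=O)C2CCc3ccccc3N2)cc1`, 56900 nM
compound 3, `O=C(Nc1ccccc1)C1CCc2ccccc2N1`, 110000 nM

Compound 3 gives the highest number of the three in a functional assay on PC-3 cells (Homo sapiens) for cytotoxicity, read by sulforhodamine B assay, with a stated time of 72 h (a lower number here means a stronger inhibitor of growth, a higher number a weaker inhibitor of growth), so it is the weakest inhibitor of growth among them. Its nearest neighbour is compound 2, whose number is lower by a margin that stays within the scatter, so the two cannot be ranked against each other. Compound 1, which carries a trifluoromethyl group on the anilide ring and an acyl group on the ring nitrogen of the shared core, lies far below, beyond the scatter.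

Compound 4, `O=C(Nc1ccccc1O)C1CCc2ccccc2N1`, has not been measured in this assay. It differs from compound 3 in one place: hydroxy in place of hydrogen on an aromatic carbon.

For the measured compounds named here, only one measured step concerns a small substituent on the anilide ring: a 1.9-fold higher number from compound 2 to compound 3 (0.29 log units; within the scatter). That step, hydrogen in place of methoxy on an aromatic carbon, stays within the scatter. A hydroxy group entering on an aromatic carbon is a comparably small change, so no step beyond the scatter is expected from compound 3 to compound 4 in this assay; the expected step is a 1.2-fold lower number from compound 3 to compound 4 (0.09 log units; within the scatter). Compound 4 is therefore estimated at 90000 nM, with a range from 30000 nM to 300000 nM.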

Compound 4, concentration for 50% growth inhibition: 4310 nM
Compound 4: the middle estimate sits 21-fold (1.32 log units) above what was measured; the measured number lies below the stated range.
By their numbers in this assay, from the lowest: compound 1; then compound 4; then compounds 2 and 3 (each within the scatter of the next).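

On this ring, a single hydroxy group ortho to a large group is enough to change the result in this assay: the step is a 26-fold lower number from compound 3 to compound 4 (1.41 log units; beyond the scatter), a large move for an entry of one heavy atom. The earlier step between methoxy and hydrogen, a 1.9-fold higher number from compound 2 to compound 3 (0.29 log units; within the scatter), gave no sign that a small substituent on this ring could matter so much, so the ring can no longer be treated as insensitive to such changes. The hydroxy step also shows that a clear gain in growth inhibition is possible without the acyl group on the ring nitrogen that compound 1 carries, although compound 1 differs from compound 4 in more than one place and the two cannot be compared directly. No measurement here explains why this one change has so large an effect.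

On these data alone, what stays open is whether the gain belongs to the hydroxy group itself or to its place ortho to a large group, since methoxy and hydroxy appear on different carbons of the ring. Nor do these compounds tell whether an amine or a fluorine on that same carbon would give a similar step, or whether hydroxy on another carbon of the ring would.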